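The source may hold more compounds than are shown below. What is called first, only, known or untested is meant among the compounds shown, and "the series" means these compounds.

Compound 1 `N#Cc1c(-c2ccccc2)nc(SCC(=O)Nn2c(COc3ccc(Cl)cc3Cl)nc3ccccc3c2=O)n(Cc2ccccc2)c1=O`, compound 2 `N#Cc1c(-c2ccc(Cl)cc2)nc(SCC(=O)Nn2c(COc3ccc(Cl)cc3Cl)nc3ccccc3c2=O)n(Cc2ccccc2)c1=O` and compound 3 `N#Cc1c(Nc2ccccc2)nc(SCC(=O)Nn2c(COc3ccc(Cl)cc3Cl)nc3ccccc3c2=O)nc1-c1ccccc1` were all tested in a functional assay on the whole organism (strain albino) for inhibition, with Rattus norvegicus as the target, read by paw edema, with stated times of 1 h and 0.5 h, at a dose of 100 mg/kg by the oral route; a lower number here means less inhibition, a higher number more inhibition at the dose given (going by the name of the read-out). Compound 1 gives 76% in this assay, compound 2 gives 61.5%, and compound 3 gives 71.2%. Among the measured compounds shown here, the only single change among the measured three is chloro in place of hydrogen on an aromatic carbon, which gave a number 14.5 percentage points lower from compound 1 to compound 2 (beyond the scatter). How the core of compound 3 differs from that of compound 1 is not broken down here; the values of compound 1 and compound 3 lie within the scatter of each other.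

Compound 4 `N#Cc1c(Nc2ccc(Cl)cc2)nc(SCC(=O)Nn2c(COc3ccc(Cl)cc3Cl)nc3ccccc3c2=O)nc1-c1ccccc1` remains unmeasured in this assay. It differs from compound 3 by chloro in place of hydrogen on an aromatic carbon, the same change as from compound 1 to compound 2, now read one bond further out as anilino to (4-chlorophenyl)amino. Because the earlier chloro for hydrogen gave a number 14.5 percentage points lower from compound 1 to compound 2 (beyond the scatter), a step of similar size is expected here, so compound 4 is estimated to show a number 14.2 percentage points lower from compound 3 to compound 4 (beyond the scatter) against compound 3. The estimate for compound 4 in this assay is therefore 57%, expected to lie between 45% and 68%.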

Compound 4, a percentage reported as inhibition, in the whole organism at one dose (the size of the read-out at that dose, not a potency): 51.9%
Compound 4: middle estimate off by 5.1 percentage points, on the high side, within the range that was stated.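

In this assay, chloro in place of hydrogen on an aromatic carbon again gave a lower number, a number 19.3 percentage points lower from compound 3 to compound 4 (beyond the scatter), so the change carried over from the core of compound 1 to the core of compound 3 with the same direction and a similar size: the same change on two cores in this assay, a number 14.5 percentage points lower (beyond the scatter) from compound 1 to compound 2 and a number 19.3 percentage points lower (beyond the scatter) from compound 3 to compound 4, 4.8 percentage points apart, within the scatter of two such steps. Among the compounds shown here, this agreement rests on only two matched pairs, each read at a single oral dose in the whole animal, so it supports transfer between these two cores and no further. It does not show that the step would hold on any other core, and it does not explain why the number falls.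

The compounds shown leave open whether fluoro, methoxy or an amine at the same place on the ring would lower the number as chloro does, or whether the fall is specific to chloro. They also leave open whether the step would keep its size at another dose.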